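The source may report more compounds than this note shows. Statements on the series, on what has been measured and on what is new or still open speak of the compounds shown alone.

Measured compounds:
Compound 1, `CC(C)CCNCCN(C(=O)[C@@H]1C[C@H]1c1ccccc1)c1ccc(-c2ccccc2)cc1`, gives 5.1 nM in a functional assay for agonist activity at G protein-coupled receptor 88 (Homo sapiens), read by HTRF and cAMP accumulation; on this read-out higher numbers stand for an effect only at larger amounts of compound and lower numbers for an effect already at smaller amounts.
Compound 2, `CC[C@H](C)[C@H](N)CN(C(=O)[C@@H]1C[C@H]1c1ccc(F)c(F)c1)c1ccc(-c2ccccc2)cc1`, gives 720 nM in this assay.
Compound 3, `CC(C)C[C@H](N)CN(C(=O)[C@@H]1C[C@H]1c1ccccc1)c1ccc(-c2cccnc2)cc1`, gives 10000 nM in this assay.

Among these three numbers, compound 3 stands highest: its value in this assay sits well beyond the scatter from compound 2, the nearest of the other two, and far beyond it from compound 1, which gives the lowest number of the set. Compound 3 is thus the least potent of the three measured compounds.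

Compound 4, `CC(C)C[C@H](N)CN(C(=O)[C@@H]1C[C@H]1c1ccccc1)c1ccc(C2=CCCCC2)cc1`, differs from compound 3 in a single place: cyclohex-1-en-1-yl in place of pyridin-3-yl on an aromatic carbon. The rest of the molecule, including the amine-bearing chain and the cyclopropane amide, is kept as in compound 3.

Among the measured compounds shown here, no pair of measured compounds differs in exactly this way, so the size of the step has to be judged from the spread of the values alone. Compound 1, which carries a carbon-only ring at this position, gives the lowest number of the set, while compound 3 with its pyridin-3-yl gives the highest, although these two compounds also differ elsewhere. On that basis a move toward a lower number is expected for compound 4, of a size beyond the scatter, described by a 25-fold lower number from compound 3 to compound 4 (1.40 log units; beyond the scatter). Compound 4 is therefore estimated at 400 nM, with a range from 40 nM to 4000 nM.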

Compound 4, half-maximal effective concentration: 1200 nM
The estimate for compound 4 lay 3.0-fold (0.48 log units) below the measured number; the measured number falls inside the stated range.
By their numbers in this assay, from the lowest: compound 1; then compounds 2 and 4 (each within the scatter of the next); then compound 3.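

In this assay, putting cyclohex-1-en-1-yl in place of pyridin-3-yl gives an 8.3-fold lower number from compound 3 to compound 4 (0.92 log units; beyond the scatter), a step beyond the scatter and the only one here that can be read with the rest of the molecule held constant. It shows that the number responds to the group on this aromatic carbon, para to a large group, even when the heavy-atom count stays the same: a six-membered non-aromatic ring of carbon only, with no hydrogen-bond acceptor, gives the lower number than the six-membered aromatic ring with its one hetero atom. Since the ring nitrogen, its hydrogen-bond acceptor and the aromatic character all leave in this one change, the step cannot be assigned to any one of them, and nothing at hand accounts for it.

As far as these compounds go, it remains open how a saturated cyclohexyl ring or a plain phenyl ring would stand at this position on the otherwise unchanged frame of compound 3, which would help separate these features. Also open, from the compounds shown here alone, is whether the step would keep its size alongside the different amine-bearing chain of compound 1.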